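A few compounds are considered here, and "the series" means these few. Any claim that something is new, unique, unknown or untested is made for them only; others in the source may bear on it.

Measured compounds:
- compound 1, `COc1cc2c(Oc3ccc(NC(=O)/C=C/S(=O)(=O)c4ccccc4F)cc3F)ccnc2cc1OCCCN1CCN(C)CC1`: 280 nM
- compound 2, `COc1cc2c(Oc3ccc(NC(=O)/C=C/S(=O)(=O)c4ccc(C)cc4)cc3F)ccnc2cc1OCCCN1CCN(C)CC1`: 2510 nM

In a functional assay on MKN-45 cells (Homo sapiens) for cytotoxicity, read by MTT assay, with a stated time of 72 h (on this read-out higher numbers stand for weaker inhibition and lower numbers for stronger inhibition), compound 1 gives 280 nM, the lowest of the two numbers shown. Its nearest neighbour is compound 2, and that single comparison, a 9.0-fold higher number from compound 1 to compound 2 (0.95 log units; beyond the scatter), concerns the ring on the sulfonyl sulfur, not the part of the molecule that changes here.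

Compound 3, `COc1cc2c(Oc3ccc(NC(=O)/C=C/S(=O)(=O)c4ccccc4F)cc3F)ccnc2cc1OCCCN1CCC(C)CC1`, has not yet been measured. It differs from compound 1 in one place: 4-methylpiperidin-1-yl in place of 4-methylpiperazin-1-yl on a saturated chain carbon, three bonds along the chain from an oxygen on an aromatic ring. For the measured compounds named here, none of the measured steps touches this chain end, so there is nothing among the measured compounds that bears directly on the change. In the absence of a comparable step, the expectation for compound 3 in this assay rests on compound 1 alone, with wide uncertainty, and a step of a 1.8-fold higher number from compound 1 to compound 3 (0.25 log units; within the scatter) is expected, which is a modest weakening that could as easily fall within the usual scatter.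

Compound 3 is therefore estimated at 500 nM, with a likely range from 150 nM to 2000 nM.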

Compound 3, half-maximal inhibitory concentration: 840 nM
Compound 3: middle estimate off by 1.7-fold (0.23 log units), on the low side; the measured number falls inside the stated range.
By their numbers in this assay, from the lowest: compound 1; then compound 3; then compound 2.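

In this assay the far end of the side chain turns out to count: a 3.0-fold higher number from compound 1 to compound 3 (0.48 log units; beyond the scatter) when 4-methylpiperidin-1-yl replaces 4-methylpiperazin-1-yl. The two rings are the same size and have the same number of heavy atoms, and the entering ring simply holds one hetero atom and one hydrogen-bond acceptor where the leaving ring holds two, so even this small exchange moves the number past the usual scatter, though the step is modest. The earlier step concerned only the ring on the sulfonyl sulfur, so this is the first sign that the 3-(4-methylpiperazin-1-yl)propyl end of the molecule matters as well, while nothing shown accounts for the weaker inhibition that comes with this change.

Going by these compounds, with one exchange at this position, it remains open how other chain ends would behave, such as a morpholine ring, a simple dimethylamino group, or the same piperazine ring on a longer chain. On these data alone, it is also open whether the same exchange would give a step of similar size with 4-methylphenyl on the sulfonyl sulfur in place of 2-fluorophenyl.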